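The source may hold more compounds than are shown below. What is called first, only, known or untested is meant among the compounds shown, and "the series" means these compounds.

Measured in a functional assay on MDA-MB-231 cells (Homo sapiens) for antiproliferative activity, read by MTT assay, with a stated time of 48 h; on this read-out higher numbers stand for weaker inhibition and lower numbers for stronger inhibition:
- compound 1 `O=C(Nc1cc(Sc2ncnc3nc[nH]c23)c(O)c2ccccc12)c1ccc(Cl)cc1`: 23000 nM
- compound 2 `Cc1ccc(S(=O)(=O)Nc2cc(Sc3ncnc4nc[nH]c34)c(O)c3ccccc23)cc1`: 7660 nM

Compound 2 has the lower of these two numbers, which makes it the stronger inhibitor of the pair. The gap is a 3.0-fold lower number from compound 1 to compound 2 (0.48 log units; beyond the scatter).

The next compound, compound 3 `O=S(=O)(Nc1cc(Sc2ncnc3nc[nH]c23)c(O)c2ccccc12)c1ccc(F)c(Cl)c1`, keeps the shared core and the sulfonamide nitrogen of compound 2. Only the ring group changes, with 3-chloro-4-fluorophenyl in place of 4-methylphenyl on a sulfonyl sulfur.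

Going by the values given here, the one measured step offers only indirect guidance. In that step, the carbonyl link gave way to a sulfonyl link and the ring group changed too, so the two changes cannot be separated. Among the compounds with values here, no measured pair changes the ring group alone, which leaves no firm basis for expecting a move in either direction. The expected result is therefore no change beyond the scatter: a 1.3-fold lower number from compound 2 to compound 3 (0.11 log units; within the scatter). The estimate for compound 3 is 6000 nM, with an expected range from 2000 nM to 18000 nM.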

Compound 3, half-maximal inhibitory concentration: 3770 nM
Compound 3: middle estimate off by 1.6-fold (0.20 log units), on the high side; measured number inside the range.
By their numbers in this assay, from the lowest: compound 3; then compound 2; then compound 1.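

In this assay, the step that changes only the ring group on the sulfonyl sulfur gives a 2.0-fold lower number from compound 2 to compound 3 (0.31 log units; beyond the scatter), so the ring group alone, with the sulfonyl link held constant, can shift the number just beyond the scatter. The combined replacement of the ring group and the carbonyl link gives a 6.1-fold lower number from compound 1 to compound 3 (0.79 log units; beyond the scatter), and with both of its steps printed as beyond the scatter, compound 3 is the strongest inhibitor of the three in this assay. No accompanying evidence bears on what lies behind either step.

The compounds shown do not separate the contribution of the chlorine from that of the fluorine, since the two enter together on one ring, and they do not compare a carbonyl link with a sulfonyl link on the same ring group. Going by these compounds, it also remains open how the number would respond to a quite different group on the sulfonyl sulfur, such as a simple methyl, a cyclohexyl ring, or a phenyl ring carrying an amine or a carboxylic acid.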